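From dimethylamino to piperidin-1-yl on compound 3

A few compounds are considered here, and "the series" means these few. Any claim that something is new, unique, unknown or untested is made for them only; others in the source may bear on it.

Compound 1 `COc1cc2c(Nc3ccc(C#N)cc3)ncnc2cc1OCCCN1CCCCC1`, compound 2 `COc1cc2c(Nc3ccc(C#N)cc3)ncnc2cc1OCCCN1CCc2ccccc2C1` and compound 3 `COc1cc2c(Nc3ccc(C#N)cc3)ncnc2cc1OCCCN1CCC(N(C)C)CC1` share one core and differ in the group on a saturated chain carbon. In a functional assay on DU-145 cells (Homo sapiens) for antiproliferative activity, read by MTT assay, with a stated time of 72 h (on this read-out lower numbers stand for stronger inhibition and higher numbers for weaker inhibition), compound 3 gives 28300 nM and compound 1 gives 24400 nM as close neighbours on the numbers shown. Compound 2 gives > 100000 nM as a limit of the assay and not a number.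

Compound 4 `COc1cc2c(Nc3ccc(C#N)cc3)ncnc2cc1OCCCN1CCC(N2CCCCC2)CC1` carries piperidin-1-yl in place of dimethylamino on a saturated ring carbon of compound 3. Putting dimethylamino on that ring carbon gave a 1.2-fold higher number from compound 1 to compound 3 (0.06 log units; within the scatter) and this is the closest guide. Swapping in 1,2,3,4-tetrahydroisoquinolin-2-yl on the chain gave an at least 4.0-fold higher number from compound 1 to compound 2 (0.61 log units; beyond the scatter) and the swap away from it gave an at least 3.5-fold lower number from compound 2 to compound 3 (0.54 log units; beyond the scatter) so one larger group did cost activity, though at another place. The expected step is therefore a 1.1-fold higher number from compound 3 to compound 4 (0.05 log units; within the scatter) with no change beyond the scatter expected. In this assay compound 4 is estimated at 32000 nM with an expected range from 13000 nM to 85000 nM for this measurement.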

Compound 4, half-maximal inhibitory concentration: 15600 nM
Compound 4: middle estimate off by 2.1-fold (0.31 log units), on the high side; measured number inside the range.
By their numbers in this assay, from the lowest: compounds 4, 1 and 3 (each within the scatter of the next). At a limit, above all of these: compound 2.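

In this assay, replacing dimethylamino with the larger piperidin-1-yl on this saturated ring carbon produces no step beyond the scatter: a 1.8-fold lower number from compound 3 to compound 4 (0.26 log units; within the scatter), and a 1.6-fold lower number from compound 1 to compound 4 (0.19 log units; within the scatter). Going by these compounds alone, the larger group seen earlier, 1,2,3,4-tetrahydroisoquinolin-2-yl, sat at another place, so compound 4 is the first to show that a second six-membered ring at this ring carbon leaves the number within the scatter, and the step of an at least 6.4-fold lower number from compound 2 to compound 4 (0.80 log units; beyond the scatter) stays beyond it. That step starts from a limit and not a number, the value of compound 2: the limit of > 100000 nM in this assay, at which 1 of the 4 values shown sits.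

The compounds shown leave open whether morpholin-4-yl or a free amino group on the same ring carbon would move the number beyond the scatter. They also leave open what a shorter or longer chain would do with this group in place.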